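Benzyl in place of diethylaminoethyl on the cyanoguanidine series

The source may hold more compounds than are shown below. What is called first, only, known or untested is meant among the compounds shown, and "the series" means these compounds.

Compound 1 `C/N=C(\NC#N)Nc1cccnc1` and compound 2 `CCN(CC)CC/N=C(\NC#N)Nc1cccnc1` share the same core and differ only by (diethylamino)methyl in place of hydrogen on a saturated chain carbon bound to a double-bonded nitrogen. In a functional assay on the whole organism (blood, strain Wistar-Okamoto) with Rattus norvegicus as the target, with a stated time of 5 days (a higher number here means that more compound is needed for the effect, a lower number that less compound is needed), compound 1 gives > 50 mg/kg, which is a limit of the assay. In this assay compound 2 gives > 8 mg/kg, again a limit of the assay and not a number. The step that the two limits leave unreadable from compound 1 to compound 2 therefore cannot be read in size, since the limit of > 50 mg/kg in this assay, at which 1 of the 2 values shown sits, and the limit of > 8 mg/kg in this assay, at which 1 of the 2 values shown sits, bracket it on both sides without fixing either end. So compound 2 stands at a limit, with no number of its own to build on.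

Compound 3 `N#CN/C(=N\Cc1ccccc1)Nc1cccnc1` is the next member, unmeasured in this assay. Its change from compound 2 is phenyl in place of (diethylamino)methyl on a saturated chain carbon bound to a double-bonded nitrogen. No measured step bears directly on it; the only step shown, from compound 1 to compound 2, is unreadable. The expectation for compound 3 thus rests on little more than the two limits, and the step that the limit leaves unreadable from compound 2 to compound 3 is expected to be small or nil beyond the scatter, in either direction. Compound 3 is estimated at 15 mg/kg, within a range from 3 mg/kg to 50 mg/kg, with a real chance that only a limit is reported.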

Compound 3, minimum effective dose: 20 mg/kg
Beside the measured number, compound 3's estimate is 1.3-fold (0.12 log units) below it, within the range that was stated.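

Going by these compounds alone, with phenyl in place of hydrogen on a saturated chain carbon bound to a double-bonded nitrogen, this assay shows an at least 2.5-fold lower number from compound 1 to compound 3 (0.39 log units; beyond the scatter), and this is the only step that can be read. Of the compounds shown, compound 3 alone has a measured minimum effective dose, so this place on the chain can carry one six-membered aromatic ring of carbon only and still give a number rather than a limit. The other steps cannot be read in size, and the value of compound 2 is a limit of the assay: the limit of > 8 mg/kg in this assay, at which 1 of the 3 values shown sits.

From the compounds shown here alone, how phenyl and (diethylamino)methyl rank at this place stays open, as does the true size of the gain over hydrogen, since only its lower bound is fixed. Cyclohexyl in place of phenyl would test whether the aromatic ring is needed, and 2-phenylethyl, a longer chain, would test how far the ring can stand from the double-bonded nitrogen.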